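A Fluoro-Methyl Swap on a Weak Cytotoxic Analogue

A few compounds are considered here, and "the series" means these few. Any claim that something is new, unique, unknown or untested is made for them only; others in the source may bear on it.

Compound 1 `C=CCn1c(=O)/c(=C\c2cccc(C)c2)[nH]c(=O)/c1=C\c1ccccc1OC` stands as the weaker of the two compounds with a number in a functional assay on BGC-823 cells (Homo sapiens) for cytotoxicity, read by CCK-8 assay, with a stated time of 72 h; a lower number here means a stronger inhibitor, a higher number a weaker inhibitor: compound 1 gives 20400 nM, whereas compound 3 `COc1ccccc1/C=c1\c(=O)[nH]/c(=C/c2cccc(Cl)c2Cl)c(=O)n1C` gives 300 nM, a gap well beyond the scatter. Compound 2 `COc1ccccc1/C=c1/[nH]c(=O)/c(=C\c2ccccc2OC)[nH]c1=O` is reported in this assay as "not active" (no number reported), with no number attached. Compound 4 `C=CCn1c(=O)/c(=C\c2cc(F)ccc2C)[nH]c(=O)/c1=C\c1ccccc1OC` is the untested partner of compound 1; the change is 5-fluoro-2-methylphenyl in place of 3-methylphenyl on a double-bonded chain carbon bound to an aromatic carbon. Going by the values given here, no measured pair in this set isolates that change, so its size cannot be read from the data. Compound 4 is expected to give about 15000 nM in this assay, within a range from 5000 nM to 50000 nM. The estimated step of a 1.4-fold lower number from compound 1 to compound 4 (0.13 log units; within the scatter) is expected to remain within the scatter, with no clear direction.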

Compound 4, half-maximal inhibitory concentration: 1600 nM
Compound 4: the middle estimate sits 9.4-fold (0.97 log units) above what was measured; measured number outside the range, below it.
By their numbers in this assay, from the lowest: compound 3; then compound 4; then compound 1.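

In this assay, going by these compounds alone, the swap of 3-methylphenyl for 5-fluoro-2-methylphenyl on a double-bonded chain carbon bound to an aromatic carbon brings a 13-fold lower number from compound 1 to compound 4 (1.11 log units; beyond the scatter) and so gives the first single-place step in this set. It shows that this position responds strongly to the aryl group it carries, and that the weak number of compound 1 is not fixed by the rest of its core. Nothing measured here bears on why the step is so large.

The fluorine and the shifted methyl arrive together in compound 4, so the compounds shown do not divide the gain between them. Going by these compounds, whether an amine or a nitrile in place of that fluorine would keep the gain remains open.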